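The source may report more compounds than this note shows. Statements on the series, on what has been measured and on what is new or still open speak of the compounds shown alone.

Measured compounds:
compound 1, `COc1cccc(OS(=O)(=O)c2ccc(N3CCN(C)C3=O)cc2)c1`, giving 2500 nM in a functional assay on HT-29 cells (Homo sapiens) for antiproliferative activity, read by sulforhodamine B assay, with a stated time of 48 h; a lower number here means a stronger inhibitor, a higher number a weaker inhibitor
compound 2, `COc1ccc(OS(=O)(=O)c2ccc(N3CCN(C)C3=O)cc2)cc1OC`, giving 12000 nM
compound 3, `CCCN1CCN(c2ccc(S(=O)(=O)Oc3cccc(OC)c3)cc2)C1=O`, giving 25000 nM

The change from compound 1 to compound 2 is methoxy in place of hydrogen on an aromatic carbon, and it brought a 4.8-fold higher number from compound 1 to compound 2 (0.68 log units; beyond the scatter). Compound 3 carries a different core: against compound 1 the difference is ethyl in place of hydrogen on a saturated chain carbon bound to an amide-type nitrogen in a ring, and it brought a 10-fold higher number from compound 1 to compound 3 (1.00 log units; beyond the scatter). Compound 3 thus has the highest number of the three.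

Compound 4, `CCCN1CCN(c2ccc(S(=O)(=O)Oc3cc(OC)cc(OC)c3)cc2)C1=O`, is not yet measured. It differs from compound 3 by methoxy in place of hydrogen on an aromatic carbon. This is the same kind of change as that from compound 1 to compound 2, but the surroundings differ: in compound 2 the entering group sits ortho to a methoxy group and para to a large group, whereas in compound 4 it sits meta to a large group and meta to a methoxy group. Resting on the single earlier instance, a 4.8-fold higher number from compound 1 to compound 2 (0.68 log units; beyond the scatter), a step of like direction is expected for compound 4: a 2.4-fold higher number from compound 3 to compound 4 (0.38 log units; beyond the scatter). Compound 3 already stands at 25000 nM, so any further rise would carry compound 4 higher than every measured number. Compound 4 is expected to give about 60000 nM, within 25000 nM to 150000 nM.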

Compound 4, half-maximal inhibitory concentration: 16000 nM
For compound 4 the middle estimate is 3.8-fold (0.57 log units) above the measured one; measured number below the stated range.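

Within this assay the same methoxy in place of hydrogen on an aromatic carbon brought a 1.6-fold lower number from compound 3 to compound 4 (0.19 log units; within the scatter) and so no change beyond the scatter on the core of compound 3. The step therefore did not carry over from the core of compound 1 to the core of compound 3, and the two instances disagree: the same change on two cores in this assay, a 4.8-fold higher number (0.68 log units; beyond the scatter) from compound 1 to compound 2 and a 1.6-fold lower number (0.19 log units; within the scatter) from compound 3 to compound 4, 7.5-fold (0.88 log units) apart, beyond the scatter of two such steps. This shows that the earlier step cannot serve as a rule for this series, but with one pair on each core it does not show what separates them, as the cores differ and the entering methoxy in compound 4 sits meta to a large group and meta to a methoxy group, unlike its place in compound 2.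

The compounds shown leave open how a hydroxyl group or a chlorine atom on the same aromatic carbon would compare with methoxy. They also leave open whether an ethyl or butyl chain in place of the propyl chain of compound 4 would give a step of either kind.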